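The compounds below may be only part of what the source reports. "The series", "measured", "known", "first", "only" and "open" are said of these compounds alone.

Measured so far:

compound 1 `Cc1cc(NC(=O)Nc2ccc(C(=O)O)cc2)c2ccccc2n1` — in an ADME assay on HepG2 cells (Homo sapiens) for cytotoxicity, with a stated time of 72 h (on this read-out higher numbers stand for an effect only at larger amounts of compound and lower numbers for an effect already at smaller amounts), compound 1 sits at the limit > 25000 nM of the assay.
compound 2 `Cc1cc(NC(=O)Nc2cc(F)ccc2F)c2ccccc2n1` — in this assay compound 2 sits at the limit > 25000 nM.
compound 3 `Cc1cc(NC(=O)Nc2ccc(C(=O)O)c(O)c2)c2ccccc2n1` — in this assay compound 3 sits at the limit > 25000 nM.

Compound 1 therefore stands only on a limit, not on a number, and so do the other two values shown: the limit of > 25000 nM in this assay, at which 3 of the 3 values shown sit. Going by the values given here, the single step between measured compounds, hydroxy in place of hydrogen on an aromatic carbon, is a step that the two limits leave unreadable from compound 1 to compound 3, and its size cannot be read because both ends are limits.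

Compound 4 `Cc1cc(NC(=O)Nc2ccc(C(C)(C)C)cc2)c2ccccc2n1` is the next compound in the series. It differs from compound 1 as follows: tert-butyl in place of carboxy on an aromatic carbon. Among the compounds with values here, no measured step in this assay touches the carboxy group or brings in a tert-butyl, so nothing measured bears on this change directly. Within the data shown here, the only guidance is that every value so far sits at the limit. Compound 4 is therefore expected to stay at or near that limit, and the step from compound 1 to compound 4 is estimated at an at least 1.2-fold lower number from compound 1 to compound 4 (0.09 log units; that floor lies within the scatter). For compound 4 the expected value in this assay is 20000 nM, within 5000 nM to 25000 nM.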

Compound 4, half-maximal effective concentration: 17000 nM
Estimate against measurement, compound 4: 1.2-fold (0.07 log units) above; the measured number falls inside the stated range.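

In this assay, going by these compounds alone, compound 4 gives 17000 nM, the first number rather than a limit, so at this place, para to a large group, tert-butyl in place of carboxy brings the read-out within the measured range. As far as these compounds go, the change reads as an at least 1.4-fold lower number from compound 1 to compound 4 (0.16 log units; that floor lies within the scatter); compound 1 stands on a limit, so only this floor can be read, and the true size of the step stays unknown. Compound 4 is the only one shown that leaves the limit: the limit of > 25000 nM in this assay, at which 3 of the 4 values shown sit.

From the compounds shown here alone, whether tert-butyl itself is needed for a measurable number stays open, since a smaller alkyl group such as methyl, or an amine, at the same place would be required to tell. Also open, going by these compounds, is how the hydroxy step would read on compound 4, where the starting value is a number rather than a limit.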